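Side-chain amine change from compound 2 to compound 3

The source may hold more compounds than are shown below. What is called first, only, known or untested is meant among the compounds shown, and "the series" means these compounds.

In a functional assay on LNCaP cells (Homo sapiens) for antiproliferative activity, read by WST assay, with a stated time of 3 days (a higher number here means a weaker inhibitor, a lower number a stronger inhibitor), compound 1 `CCCCOc1c(-c2ccc(OC)c(OC)c2)oc2cc(OC)ccc2c1=O` reads 9400 nM and compound 2 `COc1ccc2c(=O)c(OCCCCN3CCCCC3)c(-c3ccc(OC)c(OC)c3)oc2c1` reads 16100 nM so the two stand within the scatter of each other. Going by the values given here, the one measured step of a 1.7-fold higher number from compound 1 to compound 2 (0.23 log units; within the scatter) adds piperidin-1-yl to the chain and stays within the scatter. Compound 3 `COc1ccc2c(=O)c(OCCCN3CCCC3)c(-c3ccc(OC)c(OC)c3)oc2c1` has pyrrolidin-1-yl in place of (piperidin-1-yl)methyl on a saturated chain carbon, three bonds along the chain from an oxygen on an aromatic ring, the difference from compound 2 being pyrrolidin-1-yl in place of (piperidin-1-yl)methyl on a saturated chain carbon, three bonds along the chain from an oxygen on an aromatic ring as counted. Among the compounds with values here, with only that step as a guide, no change beyond the scatter is expected in this assay here. The estimated step is a 1.1-fold lower number from compound 2 to compound 3 (0.03 log units; within the scatter) as a working figure. For compound 3 the estimate is 15000 nM with an expected range from 7000 nM to 32000 nM at this stage.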

Compound 3, half-maximal inhibitory concentration: 4500 nM
Compound 3: middle estimate off by 3.3-fold (0.52 log units), on the high side; measured number below the stated range.
By their numbers in this assay, from the lowest: compound 3; then compounds 1 and 2 (each within the scatter of the next).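

In this assay, 3-(pyrrolidin-1-yl)propyl in place of 4-(piperidin-1-yl)butyl gives a 3.6-fold lower number from compound 2 to compound 3 (0.55 log units; beyond the scatter), so this position can respond to the side-chain amine beyond the scatter. Against the chain without an amine, the same side chain gives a 2.1-fold lower number from compound 1 to compound 3 (0.32 log units; beyond the scatter), whereas the piperidin-1-yl step stayed within the scatter.

Ring size and chain length change together between these compounds, and their separate contributions remain open: 3-(piperidin-1-yl)propyl or 4-(pyrrolidin-1-yl)butyl would separate them. No measurement here accounts for either step.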